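The source may hold more compounds than are shown below. What is called first, only, known or untested is meant among the compounds shown, and "the series" means these compounds.

Going by the values given here, in a functional assay on BeWo cells (Homo sapiens) for inhibition, read by MTT assay (a lower number here means a stronger inhibitor, a higher number a weaker inhibitor), compound 1 (`CC1(C)C2CCC1(C)C(OC(=O)/C=C/c1ccc(O)c(O)c1[N+](=O)[O-])C2`) gives 9310 nM and is the only compound with a number so far. Compound 2 (`O=C(/C=C/c1cc(O)c(O)c([N+](=O)[O-])c1)OCCc1ccccc1`) is recorded as "not determined" (no result reported) and so offers no number to start from. Compound 3 (`O=C(/C=C/c1cc(O)c(O)c(Br)c1)OCCc1ccccc1`) arises through the change (bromo in place of nitro on an aromatic carbon). Among the compounds with values here, no measured step shows the size of this exchange, so no step beyond the usual scatter is expected in either direction, and compound 1 at 9310 nM serves as the only anchor. For compound 3 the estimated value is 10000 nM with an expected range from 3000 nM to 35000 nM in this cell assay.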

Compound 3, half-maximal inhibitory concentration: 8240 nM
For compound 3 the middle estimate is 1.2-fold (0.08 log units) above the measured one; measured number inside the range.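

No step can be read between compound 2 and compound 3 in this assay. On these data alone, what the exchange of nitro for bromo does to the read-out stays open. No supporting evidence bears on the value of compound 3.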